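This account rests on a few compounds, and the source may have more. Where it says the series, first, only, none or still open, it means among the compounds named here.

Working notes on the series. Compound 1 `Fc1cccc(Cn2nnc3c(Br)cccc32)c1` and compound 2 `Clc1cccc2c1nnn2CC1CC1` are the two members with a number in an ADME assay on microsomes from liver (Mus musculus, strain NMRI) for metabolic stability, tested at 2.5 uM; a higher number here means faster removal of the compound, a lower number slower removal: compound 1 gives 1.3 mL/min/g and compound 2 gives 5.7 mL/min/g. Compound 3 `Fc1cccc2c1nnn2CC1CC1` has the core of compound 2 with fluoro in place of chloro; for compound 3 the outcome in this assay is "not determined" (no result reported), so compound 3 stands without a number. Compound 4 `FC(F)(F)c1cccc2c1nnn2CC1CC1` differs from compound 3 in one place: trifluoromethyl in place of fluoro on an aromatic carbon. With no value for compound 3, neither size nor direction of the step in this assay can be fixed from the data; the expectation leans on the value of compound 2 5.7 mL/min/g as the nearest measured relative. Compound 4 is expected to give about 4 mL/min/g in this assay, within 1.5 mL/min/g to 10 mL/min/g.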

Compound 4, intrinsic clearance in a liver preparation (reported as CLH), per the amount of preparation that the assay uses: 1.4 mL/min/g
Compound 4: middle estimate off by 2.9-fold (0.46 log units), on the high side; the whole stated range lies above it.
By their numbers in this assay, from the lowest: compounds 1 and 4 (each within the scatter of the next); then compound 2.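

In this assay, trifluoromethyl in place of chloro on this aromatic carbon gives a 4.1-fold lower number from compound 2 to compound 4 (0.61 log units; beyond the scatter) with the rest of the molecule unchanged. Among these compounds, this is the first sign that the group at this position can move clearance beyond the usual scatter. The step from compound 3 to compound 4 cannot be read, so fluoro remains unplaced relative to chloro and trifluoromethyl. From the compounds shown here alone, how a nitrile or a methoxy group on this carbon would behave remains open. Nothing at hand accounts for the step from chloro to trifluoromethyl.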